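Swapping the aryl group on a sulfonamide

The source may report more compounds than this note shows. Statements on the series, on what has been measured and on what is new or still open speak of the compounds shown alone.

Measured so far in a functional assay (thoracic aorta) for inhibition, with Rattus norvegicus as the target; a lower number here means a stronger inhibitor, a higher number a weaker inhibitor
Compound 1 `O=C(O)c1cc(CCCCCCCNS(=O)(=O)c2ccccc2)c2cccccc1-2` gives 18 nM
Compound 2 `CC(C)c1ccc2c(CCCCCNS(=O)(=O)c3ccccc3)cc(C(=O)O)c-2cc1` gives 120 nM
Compound 3 `CC(C)c1ccc2c(CCCCNS(=O)(=O)c3ccc(Cl)cc3)cc(C(=O)O)c-2cc1` gives 5.3 nM

Compound 3 has the lowest number of the three, and its gaps to compound 1 and compound 2 both lie beyond the usual scatter. Compound 4 `CC(C)c1ccc2c(CCCCNS(=O)(=O)c3cccc(C(F)(F)F)c3)cc(C(=O)O)c-2cc1` has 3-(trifluoromethyl)phenyl in place of 4-chlorophenyl on a sulfonyl sulfur. Among the compounds with values here, no two measured compounds differ in only one place, so no measured step shows the size of such a change. Compound 3 already sits lowest at 5.3 nM, so in this assay a modest move toward a higher number seems likelier than a further drop. The expected change is a 2.6-fold higher number from compound 3 to compound 4 (0.42 log units; beyond the scatter) (a rough estimate). For compound 4 the estimated value is 14 nM (expected range 4 nM to 50 nM).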

Compound 4, half-maximal inhibitory concentration: 1600 nM
Estimate against measurement, compound 4: 110-fold (2.06 log units) below, and the stated range ends below it.
By their numbers in this assay, from the lowest: compound 3; then compound 1; then compound 2; then compound 4.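

Within the data shown here, this is the first measured pair that differs in only one place, and it shows how much the group on the sulfonyl sulfur can matter. In this assay, putting 3-(trifluoromethyl)phenyl in place of 4-chlorophenyl gives a 300-fold higher number from compound 3 to compound 4 (2.48 log units; beyond the scatter) with the rest of the molecule unchanged. Both groups hold one six-membered aromatic ring of carbon only, yet here they are far from interchangeable.

Still open, as far as these compounds go, is how a nitrile or methoxy group on that ring would compare with compound 3. Nothing measured here explains the size of this step.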